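The source may hold more compounds than are shown below. What is called first, only, known or untested is meant among the compounds shown, and "the series" means these compounds.

Compound 1 `COc1cc(/C=C/C(=O)/C=C(/C=C/c2ccc(O)c(OC)c2)NCCCO)ccc1O` and compound 2 `COCCNC(=C\C(=O)/C=C/c1ccc(O)cc1)/C=C/c1ccc(O)cc1` share the same core, and both were tested in a functional assay on Caco-2 cells (Homo sapiens) for activation, read by fluorescence, tested at 1 uM; on this read-out lower numbers stand for a stronger effect and higher numbers for a weaker effect at the one concentration tested. In this assay compound 1 gives 93.4%, and in the same measurement compound 2 gives 94.9%. Compound 1 has the lower of these two numbers, but the gap to compound 2 is within the usual scatter, so neither can be called stronger than the other; both sit at the weak end of what this read-out can show.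

Compound 3 `COCCCNC(=C\C(=O)/C=C/c1ccc(O)c(OC)c1)/C=C/c1ccc(O)c(OC)c1` has not yet been measured. It differs from compound 1 in one place: methyl in place of hydrogen on an oxygen on a saturated carbon. Among the compounds with values here, no measured pair in this set shows what such a change does, so there is nothing to set a size against it.

Compound 3 is expected to land at 94%, somewhere from 84% to 100%. The step of a number 0.6 percentage points higher from compound 1 to compound 3 (within the scatter) is expected to stay within the scatter.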

Compound 3, a percentage reported as activity, at one concentration (the size of the read-out at that concentration, not a potency): 97.9%
Compound 3: middle estimate off by 3.9 percentage points, on the low side, and the stated range covers the measured number.
By their numbers in this assay, from the lowest: compounds 1, 2 and 3 (each within the scatter of the next).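

Within the data shown here, measured in this assay the change from hydroxy to methoxy at the end of the saturated chain gives a number 4.5 percentage points higher from compound 1 to compound 3 (within the scatter) and this is the first pair to test this position directly. Putting a methyl on that oxygen in place of hydrogen therefore has no effect that can be told from the scatter, and compound 3 sits with compound 1 at the weak end of the read-out. Nothing available here speaks to why this is so.

The compounds shown end this chain only in hydroxy or methoxy, so it remains open whether any group at this position can move the read-out at all. An amine or a carboxylic acid at the chain end, or a longer chain, would test that.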